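The source may report more compounds than this note shows. Statements on the series, on what has been measured and on what is new or still open speak of the compounds shown alone.

Of the compounds shown here, three have so far been tested in a functional assay on MCF7 cells (Homo sapiens) for cytotoxicity, read by MTT assay, with a stated time of 24 h; on this read-out higher numbers stand for weaker inhibition and lower numbers for stronger inhibition. Compound 1 `COc1cc2ncnc(Nc3ccc(F)c(Cl)c3)c2cc1OCCCSc1nc2ccccc2s1` gives 5370 nM in this assay. Compound 2 `COc1cc2ncnc(Nc3cccc(C(F)(F)F)c3)c2cc1OCCCSc1nc2ccccc2s1` differs from compound 1 in one place, (3-(trifluoromethyl)phenyl in place of 3-chloro-4-fluorophenyl on a nitrogen on an aromatic ring), and compound 2 gives 4050 nM; this is a 1.3-fold lower number from compound 1 to compound 2 (0.12 log units; within the scatter). Compound 3 `CCCCc1nc(Cl)c(CO)n1CCCOc1cc2c(Nc3ccc(F)c(Cl)c3)ncnc2cc1OC` differs from compound 1 in another place, (2-butyl-4-chloro-5-(hydroxymethyl)-1H-imidazol-1-yl in place of (1,3-benzothiazol-2-yl)sulfanyl on a saturated chain carbon, three bonds along the chain from an oxygen on an aromatic ring), and compound 3 gives 5990 nM; this is a 1.1-fold higher number from compound 1 to compound 3 (0.05 log units; within the scatter). All three numbers lie within the usual scatter of one another.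

Compound 4 `CCCCc1nc(Cl)c(CO)n1CCCOc1cc2c(Nc3cccc(C(F)(F)F)c3)ncnc2cc1OC` has not yet been measured. Among the measured compounds shown here, it differs from compound 3 in one place, (3-(trifluoromethyl)phenyl in place of 3-chloro-4-fluorophenyl on a nitrogen on an aromatic ring), which is the same change, at the same place, as the one between compound 1 and compound 2. For the measured compounds named here, only that single earlier example of the change is available, and it stayed within the scatter, so the expectation for compound 4 rests on it alone. The expected step is a 1.3-fold lower number from compound 3 to compound 4 (0.11 log units; within the scatter), close in size to the earlier 1.3-fold lower number from compound 1 to compound 2 (0.12 log units; within the scatter). Compound 4 is therefore estimated at 4600 nM in this assay, with an expected range from 2500 nM to 9000 nM.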

Compound 4, half-maximal inhibitory concentration: 8280 nM
For compound 4 the middle estimate is 1.8-fold (0.26 log units) below the measured one; the measured number falls inside the stated range.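

In this assay, putting 3-(trifluoromethyl)phenyl in place of 3-chloro-4-fluorophenyl gives a 1.4-fold higher number from compound 3 to compound 4 (0.14 log units; within the scatter), and this step cannot be told apart from the earlier one on the other core: the same change on two cores in this assay, a 1.3-fold lower number (0.12 log units; within the scatter) from compound 1 to compound 2 and a 1.4-fold higher number (0.14 log units; within the scatter) from compound 3 to compound 4, 1.8-fold (0.26 log units) apart, within the scatter of two such steps

Exchanging the group at the end of the saturated chain gives a 2.0-fold higher number from compound 2 to compound 4 (0.31 log units; beyond the scatter), which is just beyond the scatter, yet it still cannot be told apart from its earlier counterpart: the same change on two cores in this assay, a 1.1-fold higher number (0.05 log units; within the scatter) from compound 1 to compound 3 and a 2.0-fold higher number (0.31 log units; beyond the scatter) from compound 2 to compound 4, 1.8-fold (0.26 log units) apart, within the scatter of two such steps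

Each change therefore carries from one core to the other with no difference that stands out from the scatter, but each rests on a single pair of small steps, which does not prove that the two changes act independently or predict how either would behave on a further core.

The compounds shown leave open what an amine or a carboxylic acid would do in place of 2-butyl-4-chloro-5-(hydroxymethyl)-1H-imidazol-1-yl. They also leave open whether a longer chain, or a plain phenyl on the nitrogen, would produce a clearer step.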